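Nitro to hydrogen on compound 1: an expectation

The compounds below may be only part of what the source reports. "The series", "measured", "known", "first", "only" and "open" are said of these compounds alone.

The series shares the core of compound 1, `O=C(CSc1nc2ccc(NC(=O)c3ccc([N+](=O)[O-])cc3)cc2s1)NCc1ccccc1`. In a functional assay on MCF7 cells (Homo sapiens) for cytotoxicity, read by MTT assay, with a stated time of 48 h (on this read-out lower numbers stand for stronger inhibition and higher numbers for weaker inhibition), compound 1 gives > 100000 nM, which is a limit of the assay and not a number. Compound 2, `COc1ccc(CNC(=O)CSc2nc3ccc(NC(=O)c4ccc([N+](=O)[O-])cc4)cc3s2)cc1`, carries methoxy in place of hydrogen on an aromatic carbon; in this assay compound 2 gives > 100000 nM, again a limit. Compound 3, `CNC(=O)CSc1nc2ccc(NC(=O)c3ccc([N+](=O)[O-])cc3)cc2s1`, carries hydrogen in place of phenyl on a saturated chain carbon bound to an amide-type nitrogen; in this assay compound 3 gives > 100000 nM, also a limit. The steps a step that the two limits leave unreadable from compound 1 to compound 2, a step that the two limits leave unreadable from compound 1 to compound 3 and a step that the two limits leave unreadable from compound 2 to compound 3 are unreadable because of the limit of > 100000 nM in this assay, at which 3 of the 3 values shown sit. Compound 1 thus stands at the limit, with no measured value placing it anywhere else.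

Compound 4, `O=C(CSc1nc2ccc(NC(=O)c3ccccc3)cc2s1)NCc1ccccc1`, differs from compound 1 as follows: hydrogen in place of nitro on an aromatic carbon. For the measured compounds named here, none of the measured steps concerns the nitro group, and all of them are unreadable, so no measured step bears on this change and no direction can be read from the data. Given that compound 1 gives > 100000 nM, compound 4 is expected to remain at the limit. The step of a number no higher from compound 1 to compound 4 (the limit leaves the size open) is therefore estimated as none beyond the scatter. The estimate for compound 4 in this assay is 100000 nM, with a range from 30000 nM to 300000 nM.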

Compound 4, half-maximal inhibitory concentration: 35600 nM
Estimate against measurement, compound 4: 2.8-fold (0.45 log units) above; measured number inside the range.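

In this assay, for the compounds shown here, hydrogen in place of nitro gives an at least 2.8-fold lower number from compound 1 to compound 4 (0.44 log units; beyond the scatter), the first step that can be read. This position, on a six-membered aromatic ring of carbon only and para to a large group, is therefore the first place shown where a change brings a value off the limit; the changes on the other side of the shared core, in compound 2 and compound 3, left the values at the limit. The step has a known direction but an open size because compound 1 has only a limit and no number:  the limit of > 100000 nM in this assay, at which 3 of the 4 values shown sit.

The compounds shown leave open whether the same change would bring compound 2 or compound 3 off the limit, so the effect of removing nitro is known only with the benzyl amide of compound 1. They also leave open how other groups at this position would compare with hydrogen and nitro, for example an amine, a carboxylic acid or a methoxy group.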